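This account rests on a few compounds, and the source may have more. Where it says the series, first, only, none or still open, it means among the compounds named here.

Measured so far:
compound 1 `Cc1nnc(SCC(=O)c2ccccc2)n1N1C(=O)c2ccccc2C1=O` gives > 200000 nM, which is a limit of the assay and not a number.
compound 2 `Cc1nnc(SCc2ccccc2Cl)n1N1C(=O)c2ccccc2C1=O` gives > 200000 nM, again only a limit.
compound 3 `CCCc1nnc(SCc2ccccc2Cl)n1N1C(=O)c2ccccc2C1=O` gives > 200000 nM, also only a limit.

All three values come from a functional assay on A549 cells (Homo sapiens) for cytotoxicity, read by MTT assay, with a stated time of 48 h; on this read-out lower numbers stand for stronger inhibition and higher numbers for weaker inhibition. Compound 1 differs from compound 2 by benzoyl in place of 2-chlorophenyl on a saturated chain carbon bound to a sulfur; the step that the two limits leave unreadable from compound 2 to compound 1 cannot be read because the limit of > 200000 nM in this assay, at which 3 of the 3 values shown sit, covers both ends. Compound 3 differs from compound 2 by ethyl in place of hydrogen on a saturated chain carbon bound to an aromatic carbon, which is how the two cores differ. Compound 4 `CCCc1nnc(SCC(=O)c2ccccc2)n1N1C(=O)c2ccccc2C1=O`, not yet measured, differs from compound 3 by benzoyl in place of 2-chlorophenyl on a saturated chain carbon bound to a sulfur, the same change at the same place as between compound 2 and compound 1. Given (the limit of > 200000 nM in this assay, at which 3 of the 3 values shown sit), compound 4 is expected to sit at the same limit, an estimated step that the limit leaves unreadable from compound 3 to compound 4, as unreadable as a step that the two limits leave unreadable from compound 2 to compound 1. Compound 4 is expected at 300000 nM in this assay, most likely reported again as a limit.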

Compound 4, half-maximal inhibitory concentration: > 200000 nM
Compound 4 was reported as a limit (the forecaster's own chance of this, stated with the estimate: 85%); the middle value is on the limit's open side.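

No step can be read from compound 3 to compound 4 or from compound 1 to compound 4, because each value is only a limit: the limit of > 200000 nM in this assay, at which 4 of the 4 values shown sit. The compounds shown leave open whether benzoyl or the added ethyl changes cytotoxicity at all.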